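The compounds below may be only part of what the source reports. "The series", "measured", "known", "first", "only" and "open" are said of these compounds alone.

Three compounds have values in an assay on cells for inhibition of cytochrome P450 11B2, mitochondrial (Homo sapiens), read by HTRF; a higher number here means a weaker inhibitor, a lower number a stronger inhibitor:

Compound 1 `Cc1cccnc1C(=O)NCc1cncc(N2C(=O)c3ccc(Cl)cc3C2(C)C)c1` gives 9 nM.
Compound 2 `CS(=O)(=O)N[C@@H]1CCCc2c1cncc2N1CCc2cc(Cl)ccc2C1=O` gives 76 nM.
Compound 3 `Cn1cc(C(=O)N2CC(Oc3cncc(N4C(=O)c5ccc(Cl)cc5C4(C)C)c3)C2)cn1` gives 0.5 nM.

Among these three numbers compound 1 stands second highest. Compound 2 lies nearest to it, with a number that is higher by a margin beyond the usual scatter, and compound 3 lies furthest from it, with a number that is lower by a margin well beyond the scatter. Compound 1 therefore sits in the middle of the range, stronger than compound 2 but weaker than compound 3.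

Compound 4 `CCS(=O)(=O)NCc1cncc(N2C(=O)c3ccc(Cl)cc3C2(C)C)c1` has not yet been measured in this assay. It differs from compound 1 in one place: ethylsulfonyl in place of (3-methylpyridin-2-yl)carbonyl on an amine nitrogen. Within the data shown here, no measured pair shows this exact change, so its effect can only be guessed. The closest hint is compound 2, which carries a sulfonamide on a different core and gives 76 nM, a weaker number than compound 1. On that basis a modest rise in the number is expected from compound 1 to compound 4, a 2.8-fold higher number from compound 1 to compound 4 (0.44 log units; beyond the scatter), though a result within the scatter would not surprise. Compound 4 is estimated at 25 nM, with a range from 7 nM to 90 nM.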

Compound 4, half-maximal inhibitory concentration: 92 nM
Compound 4: the middle estimate sits 3.7-fold (0.57 log units) below what was measured, outside the stated range (above it).
By their numbers in this assay, from the lowest: compound 3; then compound 1; then compounds 2 and 4 (each within the scatter of the next).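

In this assay, among these compounds, the amine nitrogen on the saturated chain carbon proves sensitive to what it carries: ethylsulfonyl in place of (3-methylpyridin-2-yl)carbonyl gives a 10-fold higher number from compound 1 to compound 4 (1.01 log units; beyond the scatter) and provides the first reading of a single change, since the earlier compounds offered no pair differing in one place. The two groups have the same count of hydrogen-bond acceptors and neither has a hydrogen-bond donor, so these counts do not separate them, whereas the entering group is smaller and has no ring, and the sulfonyl replaces the carbonyl. No measurement shown here explains the size of this step.

Among the compounds shown here, the single step changes the linking group and the rest of the substituent together, so it leaves open whether the higher number follows from the sulfonyl link or from the loss of the aromatic ring. A (3-methylpyridin-2-yl)sulfonyl group or a propanoyl group on the same nitrogen would separate these two changes, as each keeps one feature of compound 1 and alters the other.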